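The source may hold more compounds than are shown below. What is called first, only, known or untested is meant among the compounds shown, and "the series" means these compounds.

In an ADME assay (liver) for metabolic stability, with Liver microsome (Rattus norvegicus) as the target, using microsomes and NADPH, with a stated time of 30 min (on this read-out higher numbers stand for fast clearance and lower numbers for slow clearance), compound 1 (`CC#C[C@H]1CN(S(=O)(=O)c2ccc(N)nc2)CCN1c1ccc(S(=O)(=O)NC)cn1`) gives 42 mL.min-1.g-1 and compound 2 (`CC#C[C@H]1CN(S(=O)(=O)c2ccc(N)nc2)CCN1c1ccc(C(=O)NC)cc1`) gives 41 mL.min-1.g-1, two values within the scatter of each other. Not yet measured, compound 3 (`CC#C[C@H]1CN(S(=O)(=O)c2ccc(N)nc2)CCN1c1ccc(C(O)(C(F)(F)F)C(F)(F)F)cn1`) carries 2,2,2-trifluoro-1-hydroxy-1-(trifluoromethyl)ethyl in place of methylsulfamoyl on an aromatic carbon, two atoms from the ring nitrogen: 2,2,2-trifluoro-1-hydroxy-1-(trifluoromethyl)ethyl in place of methylsulfamoyl on an aromatic carbon. Among the compounds with values here, no measured step covers this change, so only a modest rise in this assay is expected, and a result within the scatter would be quite possible. The expected step is a 1.3-fold higher number from compound 1 to compound 3 (0.12 log units; within the scatter). The estimate for compound 3 is 55 mL.min-1.g-1, with an expected range from 22 mL.min-1.g-1 to 135 mL.min-1.g-1.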

Compound 3, intrinsic clearance in microsomes: 42 mL.min-1.g-1
Compound 3: middle estimate off by 1.3-fold (0.12 log units), on the high side, and the stated range covers the measured number.
By their numbers in this assay, from the lowest: compounds 2, 1 and 3 (each within the scatter of the next).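

In this assay, within the data shown here, the first one-place comparison at this aromatic carbon, two atoms from the ring nitrogen, gives no change at the digits printed from compound 1 to compound 3 (within the scatter) when 2,2,2-trifluoro-1-hydroxy-1-(trifluoromethyl)ethyl, with 10 heavy atoms and no sulfur, replaces methylsulfamoyl, with 5 heavy atoms. At this position, then, this exchange leaves microsomal clearance where it was. No measurement at hand gives a cause for this result. From the compounds shown here alone, whether an amine or a carboxylic acid at this carbon would move clearance remains open, as does whether a change elsewhere on the shared core would.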